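Notes on compound 4: pyridin-3-yl for dimethylcarbamoyl

A few compounds are considered here, and "the series" means these few. Any claim that something is new, unique, unknown or untested is made for them only; others in the source may bear on it.

Measured so far in an assay for inhibition of Fatty-acid amide hydrolase 1 (Rattus norvegicus); on this read-out higher numbers stand for weaker inhibition and lower numbers for stronger inhibition:
- compound 1 `COC(=O)c1cc(-c2cnc(C(=O)CCc3ccc(-c4ccccc4)cc3)o2)ccn1` gives 1.5 nM
- compound 2 `CN(C)C(=O)c1cnc(C(=O)CCc2ccc(-c3ccccc3)cc2)o1` gives 3 nM
- compound 3 `CN(C)C(=O)c1cnc(C(=O)CCc2ccc(COc3ccccc3)cc2)o1` gives 6.7 nM

Compound 2 sits second highest of the three numbers: a 2.0-fold higher number from compound 1 to compound 2 (0.30 log units; within the scatter) is within the scatter, while a 2.2-fold higher number from compound 2 to compound 3 (0.35 log units; beyond the scatter) lies beyond it. Compound 4 `O=C(CCc1ccc(-c2ccccc2)cc1)c1ncc(-c2cccnc2)o1` differs from compound 2 as follows: pyridin-3-yl in place of dimethylcarbamoyl on an aromatic carbon. Only a 2.0-fold higher number from compound 1 to compound 2 (0.30 log units; within the scatter) bears on this change, since it also exchanges an aromatic ring for the dimethylcarbamoyl at the same place; a 2.2-fold higher number from compound 2 to compound 3 (0.35 log units; beyond the scatter) concerns another part of the molecule and is set aside. That step was within the scatter, so no change beyond the scatter is expected, with at most a slight lean toward a lower number. Compound 4 is therefore estimated at 2.2 nM (range 0.7 nM to 7 nM), which in this assay would mean a 1.4-fold lower number from compound 2 to compound 4 (0.13 log units; within the scatter).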

Compound 4, inhibition constant: 1.1 nM
Beside the measured number, compound 4's estimate is 2.0-fold (0.30 log units) above it; low and high end bracket the measured number.
By their numbers in this assay, from the lowest: compounds 4, 1 and 2 (each within the scatter of the next, the first and the last beyond it); then compound 3.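

Read in this assay, the aromatic carbon next to the ring oxygen now shows a step beyond the scatter: pyridin-3-yl in place of dimethylcarbamoyl gives a modest gain (a 2.7-fold lower number from compound 2 to compound 4 (0.44 log units; beyond the scatter)). The two aromatic groups at this place remain within the scatter of each other (a 1.4-fold lower number from compound 1 to compound 4 (0.13 log units; within the scatter)), so the methoxycarbonyl and the other ring attachment of compound 1 add nothing that can be read here. Nothing available explains the gain. Open, as far as these compounds go, is whether a carboxylic acid in place of the methyl ester of compound 1, or a morpholine at this carbon, holds the number at this level, and whether pyridin-3-yl gives the same step alongside the phenoxymethyl of compound 3.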